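Compound 1 to compound 4: a bare phenyl group

The source may hold more compounds than are shown below. What is called first, only, known or untested is meant among the compounds shown, and "the series" means these compounds.

Values in a functional assay on A549 cells (Homo sapiens) for antiproliferative activity, read by MTT assay, with a stated time of 72 h; a higher number here means a weaker inhibitor, a lower number a stronger inhibitor:
compound 1 `COc1cc(-n2cnc3ccc(-c4ccc(C)cc4F)cc32)cc(OC)c1OC`: > 10000 nM
compound 2 `COc1ccc(-c2ccc3ncn(-c4cc(OC)c(OC)c(OC)c4)c3c2)cc1O`: 200 nM
compound 3 `COc1cc(-n2cnc3ccc(-c4ccc([N+](=O)[O-])cc4)cc32)cc(OC)c1OC`: 8940 nM

Compound 1 has only a limit and no number: the limit of > 10000 nM in this assay, at which 1 of the 3 values shown sits. Compound 4 `COc1cc(-n2cnc3ccc(-c4ccccc4)cc32)cc(OC)c1OC` differs from compound 1 in one place, on an aromatic carbon of the shared core: phenyl in place of 2-fluoro-4-methylphenyl on an aromatic carbon.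

Two measured steps change this same group. The 3-hydroxy-4-methoxyphenyl group gave a large change, an at least 50-fold lower number from compound 1 to compound 2 (1.69 log units; beyond the scatter). The 4-nitrophenyl group gave only an at least 1.1-fold lower number from compound 1 to compound 3 (0.04 log units; that floor lies within the scatter), a floor that lies within the scatter. The gap between those two groups is also large, a 45-fold higher number from compound 2 to compound 3 (1.65 log units; beyond the scatter). Among the three measured compounds, only compound 2 reaches a low number, and the phenyl group of compound 4 carries neither its hydroxy nor its methoxy group. Compound 4 is therefore expected to stay close to compound 3, at 8940 nM, rather than repeat an at least 50-fold lower number from compound 1 to compound 2 (1.69 log units; beyond the scatter). It may also end at the limit of the assay. The expected step is small, at most a modest move towards a lower number: an at least 1.4-fold lower number from compound 1 to compound 4 (0.15 log units; that floor lies within the scatter). The estimate in this assay for compound 4 is 7000 nM, with an expected range of 1500 nM to 10000 nM.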

Compound 4, half-maximal inhibitory concentration: 3060 nM
The estimate for compound 4 lay 2.3-fold (0.36 log units) above the measured number, within the range that was stated.
By their numbers in this assay, from the lowest: compound 2; then compound 4; then compound 3. At a limit, above all of these: compound 1.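

In this assay, the bare phenyl ring turns out not to be a floor of activity at this position, for both substituted rings that gave high numbers lie on the weak side of it: an at least 3.2-fold lower number from compound 1 to compound 4 (0.51 log units; beyond the scatter), and a 2.9-fold lower number from compound 3 to compound 4 (0.47 log units; beyond the scatter). The 3-hydroxy-4-methoxyphenyl group still stands well apart, with a 15-fold higher number from compound 2 to compound 4 (1.18 log units; beyond the scatter), so the low number of compound 2 goes with the hydroxy and methoxy groups on the ring and not with the presence of an aromatic ring at this position alone. Compound 1 gives only a limit, so its step to compound 4 is a floor and its true size stays unknown: the limit of > 10000 nM in this assay, at which 1 of the 4 values shown sits.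

The compounds shown carry the hydroxy and methoxy groups only together, so it stays open whether either one alone accounts for the gain, or whether an amino group in place of the hydroxy would keep it. In compound 1 the fluorine and the methyl group also leave together, which leaves open what each contributes to the difference from the bare phenyl ring.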